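This account rests on a few compounds, and the source may have more. Where it says the series, first, only, none or still open, it means among the compounds named here.

Compound 1 `COC(=O)c1ccc(N(Cc2ccc(C3CCCCC3)cc2)C(=O)[C@H]2CCN2S(=O)(=O)c2c(F)c(F)c(F)c(F)c2F)cc1O` has been measured in a functional assay on MDA-MB-231 cells (Homo sapiens) for antiproliferative activity, with a stated time of 72 h (a higher number here means that more compound is needed for the effect, a lower number that less compound is needed), where compound 1 gives 2700 nM. Two companions share its core and differ only in the ring that carries the cyclohexyl group: compound 2 `COC(=O)c1ccc(N(Cc2ccc(C3CCCCC3)cn2)C(=O)[C@H]2CCN2S(=O)(=O)c2c(F)c(F)c(F)c(F)c2F)cc1O` gives 1800 nM, and compound 3 `COC(=O)c1ccc(N(Cc2cnc(C3CCCCC3)cn2)C(=O)[C@H]2CCN2S(=O)(=O)c2c(F)c(F)c(F)c(F)c2F)cc1O` gives 1600 nM. Compound 1 returns the largest of the three numbers, but the steps away from it, a 1.5-fold lower number from compound 1 to compound 2 (0.18 log units; within the scatter) and a 1.7-fold lower number from compound 1 to compound 3 (0.23 log units; within the scatter), stay within the scatter, as does a 1.1-fold lower number from compound 2 to compound 3 (0.05 log units; within the scatter); the three compounds cannot be told apart on these numbers.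

Compound 4 `O=C(NO)c1ccc(N(Cc2ccc(C3CCCCC3)cc2)C(=O)[C@H]2CCN2S(=O)(=O)c2c(F)c(F)c(F)c(F)c2F)cc1O` is not yet measured. It differs from compound 1 at the methoxycarbonyl group: hydroxyamino in place of methoxy on a carbonyl carbon. None of the three measured steps touches this part of the molecule; each of them changes the ring on the saturated chain carbon bound to the amide-type nitrogen, and each stays within the scatter. For the measured compounds named here, no measured step bears on the change to compound 4, and no direction can be read from the data. The step expected from compound 1 to compound 4 is therefore a 1.4-fold lower number from compound 1 to compound 4 (0.13 log units; within the scatter). Compound 4 is estimated at 2000 nM, with a wide range from 300 nM to 12000 nM.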

Compound 4, half-maximal effective concentration: 5100 nM
Compound 4: middle estimate off by 2.6-fold (0.41 log units), on the low side; measured number inside the range.
By their numbers in this assay, from the lowest: compounds 3, 2, 1 and 4 (each within the scatter of the next, the first and the last beyond it).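

For the compounds shown here, the earlier steps changed only the ring carrying the cyclohexyl group, so this is the first measured step at the carbonyl carbon: in this assay, hydroxyamino in place of methoxy gives a 1.9-fold higher number from compound 1 to compound 4 (0.28 log units; within the scatter). The swap takes this spot from a group with no hydrogen-bond donors to one with two, at the same heavy-atom count, yet compound 1 and compound 4 cannot be told apart on these numbers. Nothing available gives a reason for this result or shows what the change does inside the cells.

From the compounds shown here alone, it remains open whether other groups on this carbonyl carbon, such as the hydroxyl of a carboxylic acid or the amino group of a primary amide, would also stay within the scatter. Going by these compounds, it is also open whether hydroxyamino would give a similar step on the cores of compound 2 and compound 3.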